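The source may report more compounds than this note shows. Statements on the series, on what has been measured and on what is new or still open speak of the compounds shown alone.

Two compounds of this series have a number in an assay on cells for inhibition of cytochrome P450 11B2, mitochondrial (Homo sapiens); a higher number here means a weaker inhibitor, a lower number a stronger inhibitor. Compound 1 `N#Cc1ccc(C2C(=O)N(Cc3ccccc3)Cc3cncn32)cc1` gives 40 nM. Compound 2 `CC(C)OCC1n2cncc2CN([C@@H](C)c2ccc(Cl)cc2)S1(=O)=O` gives 0.8 nM, the lower of the two numbers; the gap to compound 1 lies beyond the scatter. Compound 3 `CC(C)CC1n2cncc2CN([C@@H](C)c2ccc(Cl)cc2)S1(=O)=O` carries isopropyl in place of isopropoxy on a saturated chain carbon bound to a saturated ring carbon. Within the data shown here, no step of this kind among measured compounds is available, so the direction rests on the structural change alone. For compound 3 a step of a 1.9-fold higher number from compound 2 to compound 3 (0.27 log units; within the scatter) is expected, not clearly beyond the scatter. Compound 3 is estimated at 1.5 nM, within a range of 0.4 nM to 6 nM.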

Compound 3, half-maximal inhibitory concentration: 9.4 nM
Compound 3: middle estimate off by 6.3-fold (0.80 log units), on the low side, and the stated range ends below it.
By their numbers in this assay, from the lowest: compound 2; then compound 3; then compound 1.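

Among these compounds, the change from isopropoxy to isopropyl, on a saturated chain carbon bound to a saturated ring carbon, is the first single-place step, and in this assay it gives a 12-fold higher number from compound 2 to compound 3 (1.07 log units; beyond the scatter). This place therefore responds strongly to a small edit: one oxygen atom separates isopropoxymethyl from isobutyl. Nothing measured here accounts for the size of this step.

On these data alone, it remains open whether the oxygen itself matters or the chain as a whole. A methoxy group, a longer ether chain or an amine at this place would help separate the two.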